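Fluoro to Bromo: Expecting the Next Number

This account rests on a few compounds, and the source may have more. Where it says the series, first, only, none or still open, it means among the compounds named here.

Two compounds share one core and differ only in the linking chain: compound 1 `O=C1C(=O)N(CCCCn2cc(COc3cc(=O)oc4ccccc34)nn2)c2ccc(F)cc21` and compound 2 `O=C1C(=O)N(CCCn2cc(COc3cc(=O)oc4ccccc34)nn2)c2ccc(F)cc21`. In a functional assay on HCT-116 cells (Homo sapiens) for inhibition, read by sulforhodamine B assay, with a stated time of 48 h (on this read-out lower numbers stand for stronger inhibition and higher numbers for weaker inhibition), compound 1 gives 10400 nM, and compound 2 gives 7260 nM. Of the two numbers, that of compound 2 is the smaller, though compound 1 sits within the usual scatter of it, so the two count as alike. Compound 3 `O=C1C(=O)N(CCCn2cc(COc3cc(=O)oc4ccccc34)nn2)c2ccc(Br)cc21` has not yet been measured. It keeps the chain of compound 2 and changes one substituent: bromo in place of fluoro on an aromatic carbon. Among the measured compounds shown here, no measured pair shows this kind of change, so there is no step to lean on. A modest move toward stronger inhibition in this assay seems plausible, but nothing beyond the scatter is assured. Compound 3 is therefore estimated at 5000 nM, within a range from 1500 nM to 15000 nM. That estimate corresponds to an expected step of a 1.5-fold lower number from compound 2 to compound 3 (0.16 log units; within the scatter).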

Compound 3, half-maximal inhibitory concentration: 11500 nM
For compound 3 the middle estimate is 2.3-fold (0.36 log units) below the measured one; the measured number falls inside the stated range.
By their numbers in this assay, from the lowest: compounds 2, 1 and 3 (each within the scatter of the next).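

In this assay, bromo in place of fluoro on an aromatic carbon of the six-membered aromatic ring gives a 1.6-fold higher number from compound 2 to compound 3 (0.20 log units; within the scatter) and so compound 2 and compound 3 count as alike. Among the compounds shown here, this is the first view of this position, since compound 1 and compound 2 differ only in the linking chain, and for this one pair the exchange of one halogen for the other leaves no difference that can be told from repeat measurements. Nothing available here speaks to why the two read alike.

From the compounds shown here alone, whether an amine or a carboxylic acid on the same carbon would move the number beyond the scatter stays open. So does whether bromo would read the same on the longer chain of compound 1.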